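The source may hold more compounds than are shown below. What is called first, only, known or untested is meant among the compounds shown, and "the series" means these compounds.

Measured so far in an ADME assay for permeability; on this read-out higher numbers stand for higher permeability and lower numbers for lower permeability:
compound 1 `CNC(=O)c1cc(C(=O)N[C@H]2CC[C@H](O)CC2)n([C@@H](C)c2cccc(Cl)c2)n1` gives 235 nm/s.
compound 2 `CNC(=O)c1cc(C(=O)NC2CC2)n(Cc2ccccc2)n1` gives > 80 nm/s, a limit of the assay and not a number.

Compound 2 therefore stands only at the limit of > 80 nm/s in this assay, at which 1 of the 2 values shown sits, so no number sets it against compound 1. Compound 3 `CNC(=O)c1cc(C(=O)NC2CC2)n([C@@H](C)c2ccccc2)n1` differs from compound 2 by methyl in place of hydrogen on a saturated chain carbon bound to an aromatic carbon and an aromatic nitrogen. Among the compounds with values here, no measured pair in this assay carries this change, so the size of the step is open; a step no larger than the usual scatter is expected, if anything upward. Compound 3 is expected to give about 200 nm/s, within 100 nm/s to 400 nm/s. The expected step is a step that the limit leaves unreadable from compound 2 to compound 3.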

Compound 3, apparent permeability in the ADME assay: > 400 nm/s
Compound 3: no number, only a limit; the forecaster's own chance of this, stated with the estimate: 30%; middle value at least 2.0-fold (0.30 log units) away from the limit.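

In a physicochemical assay for solubility, measured as kinetic solubility (a lower number here means a less soluble compound, a higher number a more soluble compound), compound 2 gives >= 155 ug/mL as a limit of the assay. In the physicochemical assay compound 3 gives >= 165 ug/mL as a limit too. Within the data shown here, no step from compound 2 to compound 3 can be read in the ADME assay or in the physicochemical assay as both compounds stand only at limits there. From the compounds shown here alone, the size of any shift with methyl in place of hydrogen on this saturated chain carbon stays open on both read-outs.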